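Moving to 4-fluorophenyl: what the measured neighbours suggest

The source may report more compounds than this note shows. Statements on the series, on what has been measured and on what is new or still open speak of the compounds shown alone.

In an ADME assay on MT4 cells (Homo sapiens) for cytotoxicity, read by MTT assay, with a stated time of 4 days (a lower number here means that less compound is tolerated, a higher number that more compound is tolerated), compound 1 (`COc1cccc(/C=C/C(=O)c2cc(NC(C)=O)ccc2O)c1`) gives 40000 nM while compound 2 (`CC(=O)Nc1ccc(O)c(C(=O)/C=C/c2ccccc2F)c1`) gives 33800 nM and compound 3 (`CC(=O)Nc1ccc(O)c(C(=O)/C=C/c2cccc(F)c2)c1`) gives 30100 nM so the three values lie close together. Compound 3 stands level with both others, with a 1.3-fold lower number from compound 1 to compound 3 (0.12 log units; within the scatter) and a 1.1-fold lower number from compound 2 to compound 3 (0.05 log units; within the scatter) as the two steps that reach it.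

The next structure is compound 4 (`CC(=O)Nc1ccc(O)c(C(=O)/C=C/c2ccc(F)cc2)c1`), and its difference from compound 3 is this: 4-fluorophenyl in place of 3-fluorophenyl on a double-bonded chain carbon bound to a double-bonded chain carbon while the rest stays the same. Among the compounds with values here, no measured compound yet carries the 4-fluorophenyl group. Within the data shown here, the nearest precedent is the swap of 2-fluorophenyl for 3-fluorophenyl, seen in a 1.1-fold lower number from compound 2 to compound 3 (0.05 log units; within the scatter) and the methoxy to fluoro exchange adds only a 1.3-fold lower number from compound 1 to compound 3 (0.12 log units; within the scatter) so neither points in a direction.

No change beyond the scatter is therefore expected, and the estimated step in this assay is a 1.1-fold higher number from compound 3 to compound 4 (0.03 log units; within the scatter) as a small one. For compound 4 the estimated value is 32000 nM with an expected range from 18000 nM to 55000 nM as the likely span.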

Compound 4, half-maximal cytotoxic concentration: 41100 nM
Compound 4: middle estimate off by 1.3-fold (0.11 log units), on the low side, within the range that was stated.
By their numbers in this assay, from the lowest: compounds 3, 2, 1 and 4 (each within the scatter of the next).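

With 4-fluorophenyl now in hand, all three fluorophenyl groups can be compared on a double-bonded chain carbon bound to a double-bonded chain carbon. In this assay, the exchange gives a 1.4-fold higher number from compound 3 to compound 4 (0.14 log units; within the scatter) and a 1.2-fold higher number from compound 2 to compound 4 (0.08 log units; within the scatter), so neither new step separates 4-fluorophenyl from the other two fluorophenyl groups, and with the earlier step between 2-fluorophenyl and 3-fluorophenyl also inside the scatter, the three are level in this read-out. Nothing available bears on why these groups behave alike.

The compounds shown leave open whether any group at this place can shift the number beyond the scatter. A phenyl carrying an amine or a carboxylic acid instead of fluoro would test that, as would a longer chain in place of the acetyl group on the shared core.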